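This account rests on a few compounds, and the source may have more. Where it says the series, first, only, none or still open, it means among the compounds named here.

Working notes on the series. Among the measured compounds shown here, the two compounds measured so far share a core; compound 1 is `COc1ccccc1S(=O)(=O)/C=C/c1cccnc1OC` and compound 2 is `COc1ccccc1S(=O)(=O)/C=C/c1cccnc1Cl`. In an ADME assay on BV-2 cells (Mus musculus) for cytotoxicity, with a stated time of 24 h, tested at 10 uM (on this read-out higher numbers stand for a weaker effect at the one concentration tested and lower numbers for a stronger effect), compound 1 gives 100%, and in this assay compound 2 gives 99.7%. The one step measured, a number 0.3 percentage points lower from compound 1 to compound 2 (within the scatter), lies within the scatter, so on the numbers shown compound 2 stands level with compound 1, the only other compound measured, with nothing to separate them.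

Compound 3 is `COc1ccccc1S(=O)(=O)/C=C/c1ccc(Cl)nc1Cl` and has not yet been measured in this assay. Relative to compound 2 the change is chloro in place of hydrogen on an aromatic carbon. For the measured compounds named here, the only step that bears on it is the one from compound 1 to compound 2, which also replaced a group with chloro and stayed within the scatter. A step in this assay of about a number 0.7 percentage points lower from compound 2 to compound 3 (within the scatter) is therefore expected, that is none beyond the scatter. For compound 3 a value of 99% is estimated, with a range from 88% to 105%.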

Compound 3, a percentage reported as activity, at one concentration (the size of the read-out at that concentration, not a potency): 100%
Beside the measured number, compound 3's estimate is 1 percentage points below it, within the range that was stated.
By their numbers in this assay, from the lowest: compounds 2, 1 and 3 (each within the scatter of the next).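

In this assay, among the compounds shown here, the step is a number 0.3 percentage points higher from compound 2 to compound 3 (within the scatter), so the first measured change at this position, chloro in place of hydrogen on an aromatic carbon next to the ring nitrogen and meta to a chloro group, leaves the read-out level. The earlier step concerned only the exchange of methoxy for chloro at another ring carbon; this one shows that a second chloro group on the same ring can be added with no separation beyond the scatter. No measurement on hand offers an explanation for this flat result.

Open, from the compounds shown here alone, is whether an amine, a carboxylic acid or a longer chain at this position would also stay within the scatter. Also open, going by these compounds, is whether the three compounds would remain level at any concentration other than the one tested.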